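This account rests on a few compounds, and the source may have more. Where it says the series, first, only, none or still open, it means among the compounds named here.

Measured so far:
Compound 1 `CCOC(=O)CCO/N=C(/c1ccc(OC)c(OC)c1OC)c1cccc2ccccc12`: in a functional assay on MCF7 cells (Homo sapiens) for inhibition, read by sulforhodamine B assay, with a stated time of 48 h (on this read-out higher numbers stand for weaker inhibition and lower numbers for stronger inhibition), compound 1 gives > 20000 nM, which is a limit of the assay and not a number.
Compound 2 `COc1ccc(/C(=C\c2ccc(F)cc2)c2cccc3ccccc23)c(OC)c1OC`: in this assay compound 2 gives 17700 nM.

Compound 1 thus stands at the limit of this assay; the evidence for this is the limit of > 20000 nM in this assay, at which 1 of the 2 values shown sits, so no number is known for it, only that its inhibition is weak. Compound 2 carries a different core and is not compared with compound 1 as a step here; its value simply shows weak inhibition as well.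

Compound 3 `COc1ccc(/C(=N/OCC(=O)O)c2cccc3ccccc23)c(OC)c1OC` is not yet measured. It differs from compound 1 in one place: carboxy in place of (ethoxycarbonyl)methyl on a saturated chain carbon bound to an oxygen on an unsaturated carbon. In words, carboxy replaces (ethoxycarbonyl)methyl on a saturated chain carbon bound to an oxygen on an unsaturated carbon.

Within the data shown here, no measured step is available to calibrate this change. With compound 1 already at the limit, the change is expected to give no step beyond the scatter in this assay, and compound 3 is expected to remain at or beyond the limit, with the step from compound 1 to compound 3 estimated as a step that the limit leaves unreadable from compound 1 to compound 3. Compound 3 is expected to give about 30000 nM, within a range from 10000 nM to 100000 nM.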

Compound 3, half-maximal inhibitory concentration: > 20000 nM
Compound 3: only a limit was reported; the forecaster's own chance of this, stated with the estimate: 80%; the middle value lies beyond the limit too.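

Compound 1 and compound 3 both stand at the limit of this assay, and no step between them can be read: the limit of > 20000 nM in this assay, at which 2 of the 3 values shown sit.

The compounds shown leave open whether carboxy in place of (ethoxycarbonyl)methyl changes inhibition at all, and how weak the inhibition of compound 1 and compound 3 really is.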